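Chloro for Hydrogen on the Aromatic Ring of Compound 1

The compounds below may be only part of what the source reports. "The series", "measured", "known", "first", "only" and "open" are said of these compounds alone.

Compound 1 `CN1C(=O)C2(C(C#N)=C(N)Oc3cc4oc(-c5ccccc5)cc(=O)c4c(O)c32)c2ccccc21`: in a functional assay on A549 cells (Homo sapiens) for antiproliferative activity, read by MTT assay, with a stated time of 48 h (on this read-out higher numbers stand for weaker inhibition and lower numbers for stronger inhibition), compound 1 gives > 50000 nM, a limit of the assay.
Compound 2 `Cc1ccc2c(c1)C1(C(=O)N2C)C(C#N)=C(N)Oc2cc3oc(-c4ccccc4)cc(=O)c3c(O)c21`: compound 2 gives 7060 nM.

Compound 1 stands only at a limit here, with the limit of > 50000 nM in this assay, at which 1 of the 2 values shown sits. The change chloro in place of hydrogen on an aromatic carbon yields compound 3 `CN1C(=O)C2(C(C#N)=C(N)Oc3cc4oc(-c5ccccc5)cc(=O)c4c(O)c32)c2cccc(Cl)c21`. Among the measured compounds shown here, the one measured step that bears on it, an at least 7.0-fold lower number from compound 1 to compound 2 (0.85 log units; beyond the scatter), also put a small group onto an aromatic carbon of the same core and moved the number well beyond the scatter. A step of similar direction is therefore expected, an at least 3.3-fold lower number from compound 1 to compound 3 (0.52 log units; beyond the scatter), though chloro is not methyl. Compound 3 is estimated at 15000 nM, between 4000 nM and 60000 nM.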

Compound 3, half-maximal inhibitory concentration: > 50000 nM
Compound 3 was reported as a limit; the forecaster's own chance of this, stated with the estimate: 30%; middle value at least 3.3-fold (0.52 log units) from the limit.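

Compound 1 and compound 3 both sit at a limit of this assay, so the step between them cannot be read: the limit of > 50000 nM in this assay, at which 2 of the 3 values shown sit. The compounds shown leave open whether chloro in place of hydrogen changes the activity at all.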